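The compounds below may be only part of what the source reports. "The series", "measured", "known", "first", "only" and "open" are said of these compounds alone.

Measured so far in an ADME assay on Raji cells (Homo sapiens) for cytotoxicity, read by CellTiter-Glo and resazurin assay, with a stated time of 72 h; on this read-out lower numbers stand for an effect already at smaller amounts and higher numbers for an effect only at larger amounts of compound:
compound 1 `CC(C)N(Cc1cccc(OCCCCCC(=O)O)c1)C(=O)c1ccc(-c2cccc(-c3ccccc3)c2)cc1` gives > 26000 nM, which is a limit of the assay and not a number.
compound 2 `CC(C)N(Cc1cccc(OCCCCCC(=O)O)c1)C(=O)c1ccc(-c2cccc(C(F)(F)F)c2)cc1` gives > 26000 nM, again a limit of the assay.
compound 3 `CCOC(=O)CCCCCOc1cccc(CN(C(=O)c2ccc(-c3cccc(-c4ccccc4)c3)cc2)C(C)C)c1` gives > 26000 nM, also a limit of the assay.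

Compound 3 therefore stands where every value in the series stands: all three sit at the limit of > 26000 nM in this assay, at which 3 of the 3 values shown sit, and none of them gives a number. Compound 4 is `CCOC(=O)CCCCCOc1cccc(CN(C(=O)c2ccc(-c3cccc(OC(F)(F)F)c3)cc2)C(C)C)c1` and is not yet measured. It differs from compound 3 by trifluoromethoxy in place of phenyl on an aromatic carbon. Within the data shown here, two measured steps bear on this change. The step that the two limits leave unreadable from compound 1 to compound 2 removes the same phenyl, replacing it with trifluoromethyl, but its size cannot be read from two limits. The step that the two limits leave unreadable from compound 1 to compound 3 is unreadable for the same reason. Among the measured compounds shown here, no step has a readable size, so no direction can be drawn from it; the expectation is simply that compound 4 behaves like the three measured compounds and sits at the limit rather than giving a number. Compound 4 is estimated at 40000 nM, with a range from 15000 nM to 120000 nM. The step that the limit leaves unreadable from compound 3 to compound 4 is accordingly expected to stay within the scatter.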

Compound 4, half-maximal effective concentration: > 26000 nM
Compound 4: no number, only a limit; the forecaster's own chance of this, stated with the estimate: 85%; the middle value does not contradict the limit.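

No new step can be read: compound 3 and compound 4 both give only a limit, not a number, and the whole series stands the same way: the limit of > 26000 nM in this assay, at which 4 of the 4 values shown sit. The compounds shown leave open the size and direction of every change, including trifluoromethoxy in place of phenyl.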